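The compounds below may be only part of what the source reports. "The series", "measured", "known", "first", "only" and "open" are said of these compounds alone.

In a functional assay on MCF7 cells (Homo sapiens) for cytotoxicity, read by MTT assay and propidium iodide staining, with a stated time of 24 h (on this read-out higher numbers stand for weaker inhibition and lower numbers for stronger inhibition), compound 1 `Cc1ccc(-c2nnc(SCC(=O)c3ccccc3)o2)c(O)c1` gives 150 nM, compound 3 `COc1ccc(-c2nnc(SCC(=O)c3ccc(Br)cc3)o2)c(O)c1` gives 260 nM, and compound 2 `Cc1ccc(-c2nnc(SCC(=O)c3ccc(Br)cc3)o2)c(O)c1` gives 2070 nM, the highest number of the three. Compound 4 `O=C(CSc1nnc(-c2ccnc(Cl)c2)o1)c1ccc(Br)cc1` keeps the bromo group of compound 2 and carries 2-chloropyridin-4-yl in place of 2-hydroxy-4-methylphenyl (2-chloropyridin-4-yl in place of 2-hydroxy-4-methylphenyl on an aromatic carbon). The closest measured change is the large-scale an 8.0-fold lower number from compound 2 to compound 3 (0.90 log units; beyond the scatter), made on the ring that leaves. The bromo step, a 14-fold higher number from compound 1 to compound 2 (1.14 log units; beyond the scatter), shows a similar size but is not changed here. Within the data shown here, no measured step covers a whole-ring replacement, so the direction is uncertain. A modest move to a lower number is expected, giving an estimated 2.3-fold lower number from compound 2 to compound 4 (0.36 log units; beyond the scatter). For compound 4 the estimated value is 900 nM, within a range of 150 nM to 5000 nM.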

Compound 4, half-maximal inhibitory concentration: 270 nM
The estimate for compound 4 lay 3.3-fold (0.52 log units) above the measured number; low and high end bracket the measured number.
By their numbers in this assay, from the lowest: compounds 1, 3 and 4 (each within the scatter of the next); then compound 2.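

In this assay, 2-chloropyridin-4-yl in place of 2-hydroxy-4-methylphenyl gives a 7.7-fold lower number from compound 2 to compound 4 (0.88 log units; beyond the scatter), the first whole-ring replacement at this position, so a ring with a hydrogen-bond donor is not needed for a lower number. With the bromo group kept, compound 3 at 260 nM and compound 4 at 270 nM lie within the scatter of each other, despite their different rings. No evidence here explains the step.

The compounds shown do not separate the part played by the ring nitrogen from that of the chlorine. On these data alone, whether an amine or a methoxy group in place of the chlorine would keep this number also remains open.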